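Dropping one methyl from the amine of compound 2

A few compounds are considered here, and "the series" means these few. Any claim that something is new, unique, unknown or untested is made for them only; others in the source may bear on it.

The account follows a single change made to compound 2 `CN(C)c1ncnc2c1c(-c1ccoc1)cn2[C@@H]1O[C@H](CO)[C@@H](O)[C@H]1O`, whose potency was read in a functional assay on HCT-116 cells (Homo sapiens), read by MTT assay, with a stated time of 72 h; a higher number here means a weaker inhibitor, a lower number a stronger inhibitor. In this assay compound 2 gives > 20000 nM, which is a limit of the assay rather than a number. Its two measured relatives stand at the same place. Compound 1 `CN(C)c1ncnc2c1c(-c1ccsc1)cn2[C@@H]1O[C@H](CO)[C@@H](O)[C@H]1O` gives > 20000 nM in this assay, again a limit. Compound 3 `CN(C)c1ncnc2c1c(-c1cccs1)cn2[C@@H]1O[C@H](CO)[C@@H](O)[C@H]1O` gives > 20000 nM in this assay, also a limit. Thus (the limit of > 20000 nM in this assay, at which 3 of the 3 values shown sit), and the three steps that connect them cannot be sized: a step that the two limits leave unreadable from compound 1 to compound 2, a step that the two limits leave unreadable from compound 1 to compound 3 and a step that the two limits leave unreadable from compound 2 to compound 3.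

Compound 4 `CNc1ncnc2c1c(-c1ccoc1)cn2[C@@H]1O[C@H](CO)[C@@H](O)[C@H]1O` has not yet been measured. It differs from compound 2 as follows:

hydrogen in place of methyl on a nitrogen on an aromatic ring

For the measured compounds named here, none of the measured steps touches this nitrogen; all three exchange the aryl group on the aromatic carbon, and none yields a readable size. So no measured step bears on the change, and the expectation rests only on the three limits already seen. Compound 4 is expected to remain near the limit in this assay, the step of an at least 1.3-fold lower number from compound 2 to compound 4 (0.12 log units; that floor lies within the scatter) being an estimate with little support. The estimated value for compound 4 is 15000 nM, within a range from 1000 nM to 40000 nM.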

Compound 4, half-maximal inhibitory concentration: > 20000 nM
Compound 4: no number, only a limit; the forecaster's own chance of this, stated with the estimate: 60%; at least 1.3-fold (0.12 log units) between middle value and limit.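

In this assay compound 4 gives > 20000 nM, which is a limit of the assay and not a number. Compound 2 sits at the same limit, and the step between the two cannot be read. The compounds shown leave open how potent any of them actually is, and whether going from dimethylamino to methylamino changes potency at all in this assay.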